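Isopropyl for oxanylethyl on the aromatic nitrogen of the series

A few compounds are considered here, and "the series" means these few. Any claim that something is new, unique, unknown or untested is made for them only; others in the source may bear on it.

Three compounds of the shared core have numbers in a physicochemical assay for lipophilicity, using the shake flask method, measured as octanol-water partition, at pH 7.4; a higher number here means a more lipophilic compound, a lower number a more polar compound. Compound 1 `CC(C)n1cc(-c2ccnc3[nH]c(C4CCNCC4)cc23)ccc1=O` gives -0.2. Compound 2 `CC(=O)N1CCC(c2cc3c(-c4ccc(=O)n(C(C)C)c4)ccnc3[nH]2)CC1` gives 2.1. Within the data shown here, the only step between two compounds that differ in one place is a number 2.30 log units higher from compound 1 to compound 2 (beyond the scatter). Compound 3 `CN(C)C(=O)CN1CCC(c2cc3c(-c4ccc(=O)n(CCC5CCOCC5)c4)ccnc3[nH]2)CC1` gives 1.5 in this assay, which places it second highest of the three: compound 2 stands higher, compound 1 stands well lower, both gaps beyond the scatter.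

Compound 4 `CC(C)n1cc(-c2ccnc3[nH]c(C4CCN(CC(=O)N(C)C)CC4)cc23)ccc1=O` is not yet measured. It differs from compound 3 in one place: isopropyl in place of 2-(oxan-4-yl)ethyl on an aromatic nitrogen. Among the measured compounds shown here, the one measured step concerns the amine nitrogen in a ring and not the aromatic nitrogen, so no step bears directly on this change. Compound 2 and compound 3 differ in two places at once; compound 2 gives 2.1 and compound 3 gives 1.5, and that gap cannot be separated into parts. The change removes a ring with one oxygen and several carbons and brings in a short chain of three carbons.

The expectation for compound 4 is therefore a modest step, a number 0.30 log units lower from compound 3 to compound 4 (within the scatter), likely a small decrease, with direction not secure. Compound 4 is estimated at 1.2, in the range 0.6 to 1.8.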

Compound 4, distribution coefficient: 1.9
Compound 4: the middle estimate sits 0.70 log units below what was measured, outside the stated range (above it).
By their numbers in this assay, from the lowest: compound 1; then compound 3; then compounds 4 and 2 (each within the scatter of the next).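

In this assay, among these compounds, isopropyl in place of 2-(oxan-4-yl)ethyl on the aromatic nitrogen gives a number 0.40 log units higher from compound 3 to compound 4 (beyond the scatter) and is the first reading of this position, with the group on the amine nitrogen held constant and the smaller group giving the higher number. With isopropyl held constant on the aromatic nitrogen, (dimethylcarbamoyl)methyl in place of acetyl on the amine nitrogen gives a number 0.20 log units lower from compound 2 to compound 4 (within the scatter) and so does not separate these two groups, whereas (dimethylcarbamoyl)methyl in place of hydrogen gives a number 2.10 log units higher from compound 1 to compound 4 (beyond the scatter) and joins a number 2.30 log units higher from compound 1 to compound 2 (beyond the scatter) as a second large step from the free ring amine. Nothing available explains any of these steps.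

Whether the step at the aromatic nitrogen carries over when acetyl or hydrogen sits on the amine nitrogen remains open, as only one such pair is shown. A 2-cyclohexylethyl group on the aromatic nitrogen would help separate the ring oxygen from the size of the group, and a carboxylic acid on the amine nitrogen side chain would test how far the large step from the free ring amine extends.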